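Nitro to methyl: compound 1 to compound 3

This account rests on a few compounds, and the source may have more. Where it says the series, first, only, none or still open, it means among the compounds named here.

Within the data shown here, in a functional assay on MCF7 cells (Homo sapiens) for antiproliferative activity, read by trypan blue exclusion, with a stated time of 24 h (a higher number here means a weaker inhibitor, a lower number a stronger inhibitor), compound 1 `O=C1NC(=O)/C(=C/c2cn(Cc3ccc([N+](=O)[O-])cc3)c3ccccc23)N1` gives 10900 nM and compound 2 `O=C1NC(=O)/C(=C/c2cn(Cc3ccccc3)c3ccc(Br)cc23)N1` gives 7600 nM, two numbers within the scatter of each other, so compound 1 stands level with the only other measured compound. Compound 3 `Cc1ccc(Cn2cc(/C=C3\NC(=O)NC3=O)c3ccccc32)cc1` carries methyl in place of nitro on an aromatic carbon, para to a large group (methyl in place of nitro on an aromatic carbon). Among the measured compounds shown here, no measured pair shows the effect of this change, so only a small move toward a lower number is expected, probably none beyond the scatter. The expected step is a 1.4-fold lower number from compound 1 to compound 3 (0.13 log units; within the scatter). For compound 3 the estimated value is 8000 nM, with an expected range from 3000 nM to 20000 nM.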

Compound 3, half-maximal inhibitory concentration: 20200 nM
Compound 3: the middle estimate sits 2.5-fold (0.40 log units) below what was measured; the whole stated range lies below it.
By their numbers in this assay, from the lowest: compounds 2, 1 and 3 (each within the scatter of the next, the first and the last beyond it).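

In this assay, among these compounds, the change from 4-nitrophenyl to 4-methylphenyl gives a 1.9-fold higher number from compound 1 to compound 3 (0.27 log units; within the scatter), the first measured step at this position. In this pair, methyl, with no hydrogen-bond acceptors, stands level with nitro, with its two, so the acceptors of nitro are not required for activity at this level. No available measurement bears on the cause of this result.

From the compounds shown here alone, whether an amine, a carboxylic acid or a methoxy group at this position would move beyond the scatter remains open. Going by these compounds, the effect of the same change on other carbons of this ring also remains open.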